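Series notes: imidazolyl for bromo, compound 2 to compound 3

The compounds below may be only part of what the source reports. "The series", "measured", "known", "first", "only" and "open" are said of these compounds alone.

Compound 1, `CC(/N=c1\c(O)c(O)\c1=N/c1cccnc1)C(C)(C)C`: 1950 nM
Compound 2, `CC(/N=c1\c(O)c(O)\c1=N/c1ccc(Br)cc1)C(C)(C)C`: 1260 nM

In a functional assay for inhibition, with Rattus norvegicus as the target (on this read-out lower numbers stand for stronger inhibition and higher numbers for weaker inhibition), compound 2 and compound 1 sit within the scatter of each other, the step being a 1.5-fold lower number from compound 1 to compound 2 (0.19 log units; within the scatter). Compound 3, `CC(/N=c1\c(O)c(O)\c1=N/c1ccc(-n2ccnc2)cc1)C(C)(C)C`, differs from compound 2 by 1H-imidazol-1-yl in place of bromo on an aromatic carbon. Within the data shown here, the only measured step, a 1.5-fold lower number from compound 1 to compound 2 (0.19 log units; within the scatter), exchanges the aryl ring itself and bears only loosely on this change; no measured step replaces the bromo group. In this assay no step beyond the scatter is therefore expected, in either direction. Compound 3 is estimated at 1500 nM, with a range of 500 nM to 4500 nM. That estimate means an expected 1.2-fold higher number from compound 2 to compound 3 (0.08 log units; within the scatter).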

Compound 3, half-maximal inhibitory concentration: > 30000 nM
Compound 3 ended at the assay's limit; the forecaster's own chance of this, stated with the estimate: 5%; middle value at least 20-fold (1.30 log units) from the limit.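

On the aromatic carbon para to a large group, the series proves sensitive to the substituent: 1H-imidazol-1-yl in place of bromo gives an at least 23-fold higher number from compound 2 to compound 3 (1.37 log units; beyond the scatter). The earlier exchange of the aryl ring, a 1.5-fold lower number from compound 1 to compound 2 (0.19 log units; within the scatter), gave no sign of such sensitivity. In this assay compound 3 gives > 30000 nM, which is a limit of the assay and not a number, and the full size of the step stays unread: the limit of > 30000 nM in this assay, at which 1 of the 3 values shown sits.

Open, as far as these compounds go, is how a chloro, a methoxy or a phenyl group would read on this carbon. Those values would help show whether the five-membered ring as such or its nitrogen atoms go with the loss.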